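Swapping Trifluoromethyl for Chloro on the Aryl Urea

A few compounds are considered here, and "the series" means these few. Any claim that something is new, unique, unknown or untested is made for them only; others in the source may bear on it.

Compound 2 `COc1cc2cc(Oc3ccc(NC(=O)Nc4ccc(Cl)c(C(F)(F)F)c4)cc3)c(C)nc2cc1OC` is one of two diaryl ureas measured in a functional assay on T47D cells (Homo sapiens) for inhibition, read by sulforhodamine B assay, with a stated time of 48 h (on this read-out lower numbers stand for stronger inhibition of growth and higher numbers for weaker inhibition of growth), where compound 2 gives 7900 nM. Its companion, compound 1 `COc1cc2cc(Oc3ccc(NC(=O)Nc4cccc(C(F)(F)F)c4)cc3)c(C)nc2cc1OC`, carries hydrogen where compound 2 carries the chloro group, and in this assay compound 1 gives 6680 nM. Among the compounds with values here, the single measured step, a 1.2-fold higher number from compound 1 to compound 2 (0.07 log units; within the scatter), lies within the scatter, so compound 2 stands alongside compound 1 with nothing to separate the two. Compound 3 `COc1cc2cc(Oc3ccc(NC(=O)Nc4ccc(Cl)c(Cl)c4)cc3)c(C)nc2cc1OC` differs from compound 2 by one replacement: chloro in place of trifluoromethyl on an aromatic carbon. Within the data shown here, no measured step bears directly on this exchange; the only step available, a 1.2-fold higher number from compound 1 to compound 2 (0.07 log units; within the scatter), concerned the chloro group alone and was within the scatter. The expected outcome is therefore no step beyond the scatter, a 1.0-fold higher number from compound 2 to compound 3 (0.01 log units; within the scatter). Compound 3 is estimated to give about 8000 nM in this assay, within a range from 3000 nM to 20000 nM.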

Compound 3, concentration for total growth inhibition: 10100 nM
The estimate for compound 3 lay 1.3-fold (0.10 log units) below the measured number; measured number inside the range.
By their numbers in this assay, from the lowest: compounds 1, 2 and 3 (each within the scatter of the next).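

In this assay the exchange of trifluoromethyl for chloro, on an aromatic carbon ortho to a chloro group, gives a 1.3-fold higher number from compound 2 to compound 3 (0.11 log units; within the scatter) and so shows that this position, untouched by the earlier step, accepts either group without a change beyond the scatter. The comparison of 3,4-dichlorophenyl with 3-(trifluoromethyl)phenyl on the urea nitrogen gives a 1.5-fold higher number from compound 1 to compound 3 (0.18 log units; within the scatter) and likewise stays within the scatter, which leaves all three compounds unseparated on this read-out. Nothing available here speaks to the reason for this flat picture.

Still open, from the compounds shown here alone, is whether, in this assay, a different kind of group on this aromatic carbon, such as an amine or a carboxylic acid, would move the number beyond the scatter. Also open, going by these compounds, is whether the exchange of trifluoromethyl for chloro would stay within the scatter with the shared core altered.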